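The source may report more compounds than this note shows. Statements on the series, on what has been measured and on what is new or still open speak of the compounds shown alone.

Measured so far:
- compound 1, `Cc1ccncc1-c1ccc2[nH]c(=O)nc(-c3ccccc3)c2c1`: > 50000 nM
- compound 2, `Cn1ccc(-c2cccc3[nH]c(=O)nc(-c4ccccc4)c23)n1`: > 50000 nM

Both numbers come from an ADME assay on L6 cells (Rattus norvegicus) for cytotoxicity, read by fluorescence and resazurin assay, with a stated time of 72 h (on this read-out lower numbers stand for an effect already at smaller amounts and higher numbers for an effect only at larger amounts of compound), and both are limits of the assay rather than measured values. For compound 1 the result > 50000 nM is such a limit. For compound 2 the result > 50000 nM is a limit of the same kind. This puts compound 1 nowhere in particular on a scale: the limit of > 50000 nM in this assay, at which 2 of the 2 values shown sit, so there is no ordering to read between the two compounds, only that neither showed an effect within the range the assay covers.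

Compound 3, `O=c1nc(-c2ccccc2)c2cc(N3CCNCC3)ccc2[nH]1`, has not yet been tested. Compared with compound 1 the change is piperazin-1-yl in place of 4-methylpyridin-3-yl on an aromatic carbon on the shared core. Among the compounds with values here, no pair of measured compounds shows what such a change does in this assay, and the two known results give no measured number to start from. For this assay the expectation is therefore no step beyond the usual scatter, with the result most likely again a limit; the step from compound 1 to compound 3 is estimated as a number no higher from compound 1 to compound 3 (the limit leaves the size open). Compound 3 is expected to give about 50000 nM, with a range from 15000 nM to 150000 nM.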

Compound 3, half-maximal effective concentration: > 25000 nM
Compound 3: no number, only a limit; the forecaster's own chance of this, stated with the estimate: 80%; the middle value lies beyond the limit too.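

In this assay compound 3 gives > 25000 nM, which is a limit and not a number. Compound 1 also gives only a limit, and no step can be read between compound 1 and compound 3. The compounds shown leave open what piperazin-1-yl in place of 4-methylpyridin-3-yl does to the concentration needed for an effect on these cells.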